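A few compounds are considered here, and "the series" means these few. Any claim that something is new, unique, unknown or untested is made for them only; others in the source may bear on it.

Measured so far:
Compound 1 `CCOC(=O)N1N=C(c2ccccc2)CC1c1cc(OC)c(OC)c(OC)c1`: 6720 nM
Compound 2 `CCOC(=O)N1N=C(c2cccc(OC)c2)CC1c1cc(OC)c(OC)c(OC)c1`: 7300 nM
Compound 3 `COC(=O)N1N=C(c2ccccc2)CC1c1ccc(OC)cc1`: > 10000 nM, which is a limit of the assay and not a number

All three were tested in a functional assay on A2780 cells (Homo sapiens) for antiproliferative activity, read by MTT assay, with a stated time of 48 h; on this read-out higher numbers stand for weaker inhibition of growth and lower numbers for stronger inhibition of growth. The step of a 1.1-fold higher number from compound 1 to compound 2 (0.04 log units; within the scatter) comes from one change, (methoxy in place of hydrogen on an aromatic carbon). For compound 3 this assay reports only a limit, (the limit of > 10000 nM in this assay, at which 1 of the 3 values shown sits). The difference between the core of compound 1 and the core of compound 3 is not broken down here.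

Compound 4 `COC(=O)N1N=C(c2ccccc2)CC1c1ccc(OC)c(OC)c1` has not yet been measured. It differs from compound 3 by methoxy in place of hydrogen on an aromatic carbon. This is the same kind of change as from compound 1 to compound 2, though here the place is also ortho to a methoxy group (2 heavy atoms), which was not so before. Because the earlier step of a 1.1-fold higher number from compound 1 to compound 2 (0.04 log units; within the scatter) lay within the scatter, the step to compound 4 is expected to be small as well, about a step that the limit leaves unreadable from compound 3 to compound 4. Compound 4 is therefore estimated at roughly 12000 nM in this assay, most likely between 4000 nM and 40000 nM, with a fair chance that only a limit is again reported.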

Compound 4, concentration for 50% growth inhibition: 29900 nM
The estimate for compound 4 lay 2.5-fold (0.40 log units) below the measured number; measured number inside the range.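

The step from compound 3 to compound 4 cannot be read, since compound 3 has only a limit: the limit of > 10000 nM in this assay, at which 1 of the 4 values shown sits. On these data alone, whether methoxy in place of hydrogen at this place changes growth inhibition on the core of compound 3 stays open.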